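Working notes on clearance: the next analogue

The source may report more compounds than this note shows. Statements on the series, on what has been measured and on what is new or still open speak of the compounds shown alone.

Measured in an ADME assay on microsomes from liver (Homo sapiens) for metabolic stability, read by LC-MS, tested at 1 uM; on this read-out lower numbers stand for slow clearance and higher numbers for fast clearance:
- compound 1 `NCCCCCOc1ccc([C@H]2CC[C@]3(CC2)OOC2(O3)C3CC4CC(C3)CC2C4)cc1`: < 7 mL.min-1.g-1 (a limit)
- compound 2 `NC(=O)C1CCN(Cc2ccc([C@H]3CC[C@]4(CC3)OOC3(O4)C4CC5CC(C4)CC3C5)cc2)CC1`: 10 mL.min-1.g-1
- compound 3 `NC1CCN(S(=O)(=O)c2ccc([C@H]3CC[C@]4(CC3)OOC3(O4)C4CC5CC(C4)CC3C5)cc2)CC1`: < 7 mL.min-1.g-1 (a limit)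

Compound 3 has no number on this read-out, only the limit < 7 mL.min-1.g-1. For the measured compounds named here, compound 1 is the one other compound held at a limit.

Compound 4 `CC(C)(CN)Oc1ccc([C@H]2CC[C@]3(CC2)OOC2(O3)C3CC4CC(C3)CC2C4)cc1` carries 1-(aminomethyl)-1-methylethoxy in place of (4-aminopiperidin-1-yl)sulfonyl, on an aromatic carbon para to a large group (1-(aminomethyl)-1-methylethoxy in place of (4-aminopiperidin-1-yl)sulfonyl on an aromatic carbon).

Going by the values given here, three measured steps bear on this change. The swap closest to it is a step that the two limits leave unreadable from compound 1 to compound 3. The other two are an at least 1.4-fold higher number from compound 1 to compound 2 (0.15 log units; that floor lies within the scatter) and an at least 1.4-fold lower number from compound 2 to compound 3 (0.15 log units; that floor lies within the scatter). From the compounds shown here alone, their sizes stay open because of the limit of < 7 mL.min-1.g-1 in this assay, at which 2 of the 3 values shown sit. Compound 1, whose (5-aminopentyl)oxy is the group most like the entering one, stands at the limit < 7 mL.min-1.g-1. Only compound 2 has a number, and its steps to the other two do not clear the scatter.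

In this assay the expected change is therefore none beyond the scatter, with the estimated step being a number no lower from compound 3 to compound 4 (the limit leaves the size open). A report of a limit alone is more likely than not. The estimate for compound 4 is 7 mL.min-1.g-1, with an expected range from 4 mL.min-1.g-1 to 15 mL.min-1.g-1.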

Compound 4, intrinsic clearance in microsomes: < 7 mL.min-1.g-1
Compound 4 was reported as a limit; the forecaster's own chance of this, stated with the estimate: 60%; the middle value sits exactly at the limit.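

At this position on the aromatic carbon, the ringless 1-(aminomethyl)-1-methylethoxy joins (5-aminopentyl)oxy and (4-aminopiperidin-1-yl)sulfonyl in giving only a limit in this assay, so a limit is reported with or without a ring or sulfonyl in the group. For the compounds shown here, compound 2 is the one compound that goes against this pattern, yet the measured comparison is an at least 1.4-fold lower number from compound 2 to compound 4 (0.15 log units; that floor lies within the scatter). The steps from compound 3 to compound 4 and from compound 1 to compound 4 cannot be read, because both ends of each step are limits: the limit of < 7 mL.min-1.g-1 in this assay, at which 3 of the 4 values shown sit.

From the compounds shown here alone, the actual clearance of compound 1, compound 3 and compound 4 stays open, and with it any order among them. Also open, going by these compounds, is whether a carboxylic acid or a dimethylamino group in place of the primary amine of 1-(aminomethyl)-1-methylethoxy would give a readable number, and whether the number of compound 2 goes with the carbamoyl or with the methyl link in (4-carbamoylpiperidin-1-yl)methyl.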